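Dopamine transporter binding: ring size and para substituent

This account rests on a few compounds, and the source may have more. Where it says the series, first, only, none or still open, it means among the compounds named here.

Measured so far:
compound 1 `COC(=O)C1=C(c2ccc(C(C)(C)C)cc2)CCC1` — 302000 nM
compound 2 `COC(=O)C1=C(c2ccc(OC(F)(F)F)cc2)CCC1` — 2650000 nM
compound 3 `COC(=O)C1=C(c2ccc(C(C)(C)C)cc2)CCCC1` — 605000 nM

In an assay on COS-1 cells for displacement of a labelled ligand from sodium-dependent dopamine transporter (Homo sapiens) (on this read-out lower numbers stand for stronger inhibition and higher numbers for weaker inhibition), compound 1 gives 302000 nM. Compound 2 carries trifluoromethoxy in place of tert-butyl on an aromatic carbon and gives 2650000 nM, so that an 8.8-fold higher number from compound 1 to compound 2 (0.94 log units; beyond the scatter). Compound 3 shares the substituent of compound 1 on a different core; the difference between the two cores is not broken down here. The value of compound 3, 605000 nM, and that of compound 1 lie within the scatter.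

Compound 4 `COC(=O)C1=C(c2ccc(OC(F)(F)F)cc2)CCCC1` carries trifluoromethoxy in place of tert-butyl on an aromatic carbon on the core of compound 3. The two place lines differ: para to a large group here, para to a group of 9 heavy atoms before, so this is the same kind of change, not the same. Compound 4 is expected to show a step of about an 8.3-fold higher number from compound 3 to compound 4 (0.92 log units; beyond the scatter), resting on the earlier 8.8-fold higher number from compound 1 to compound 2 (0.94 log units; beyond the scatter). The estimate for compound 4 is 5000000 nM, from 1500000 nM to 15000000 nM.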

Compound 4, inhibition constant: 1660000 nM
Estimate against measurement, compound 4: 3.0-fold (0.48 log units) above, and the stated range covers the measured number.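

In this assay, trifluoromethoxy in place of tert-butyl on the core of compound 3 moves the read-out in the same direction as on the core of compound 1 (a 2.7-fold higher number from compound 3 to compound 4 (0.44 log units; beyond the scatter)). The direction carries across these two cores, but the size of the step does not: the same change on two cores in this assay, an 8.8-fold higher number (0.94 log units; beyond the scatter) from compound 1 to compound 2 and a 2.7-fold higher number (0.44 log units; beyond the scatter) from compound 3 to compound 4, 3.2-fold (0.50 log units) apart, beyond the scatter of two such steps

For the compounds shown here, with only two cores, this pair does not show why the step size differs or how the change would behave on a further core.

Still open, as far as these compounds go, is how other groups at this place compare with tert-butyl and trifluoromethoxy, for example an amine or a carboxylic acid. The compounds shown also leave open what replacing the methyl ester with an amide or a carboxylic acid would do on either core.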